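A few compounds are considered here, and "the series" means these few. Any claim that something is new, unique, unknown or untested is made for them only; others in the source may bear on it.

Compound 1 `CC(C)CSc1nc(N)nc2c1ncn2/C=C1/CC1(CO)CO`: 60000 nM
Compound 2 `C=CCOc1nc(N)nc2c1ncn2/C=C1/CC1(CO)CO`: > 20000 nM
Compound 3 `CC(C)CNc1nc(N)nc2c1ncn2/C=C1/CC1(CO)CO`: > 20000 nM

In an ADME assay on CCRF-HSB-2 cells (Homo sapiens) for cytotoxicity, with a stated time of 7 days (on this read-out higher numbers stand for lower toxicity in this test and lower numbers for higher toxicity in this test), compound 1 gives 60000 nM. For compound 2 the result is only a limit, > 20000 nM. For compound 3 the result is likewise only a limit, > 20000 nM. Compound 2 thus stands at the limit of > 20000 nM in this assay, at which 2 of the 3 values shown sit, and no number is read for it. The step that the limit leaves unreadable from compound 1 to compound 2 cannot be sized, nor can a step that the limit leaves unreadable from compound 1 to compound 3 or a step that the two limits leave unreadable from compound 2 to compound 3.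

Compound 4 `CC(C)Sc1nc(N)nc2c1ncn2/C=C1/CC1(CO)CO` has not yet been tested in this assay. It differs from compound 2 as follows: isopropylsulfanyl in place of allyloxy on an aromatic carbon. Among the compounds with values here, of the measured steps, the one from compound 1 to compound 2 bears most closely on this change, since it exchanges an alkylsulfanyl group for allyloxy in the opposite direction, but the limit leaves its size hidden. Within the data shown here, the only number available for an alkylsulfanyl analogue comes from compound 1, which gives 60000 nM. On that basis compound 4 is expected to land near 50000 nM, within a range of 20000 nM to 150000 nM. The expected step that the limit leaves unreadable from compound 2 to compound 4 cannot be called a change beyond the scatter, since compound 2 holds only a limit; a limit-only reading for compound 4 is itself quite possible.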

Compound 4, half-maximal cytotoxic concentration: 94000 nM
Compound 4: the middle estimate sits 1.9-fold (0.27 log units) below what was measured; the range from low to high includes it.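

In this assay, within the data shown here, the exchange of isobutyl for isopropyl on a sulfur gives the first step in this set that can be sized: a 1.6-fold higher number from compound 1 to compound 4 (0.19 log units; within the scatter). At this position, on an aromatic carbon of the six-membered aromatic ring with 2 nitrogen, the two alkylsulfanyl groups therefore cannot be told apart in this read-out, so removing this much of the branched chain leaves no change beyond the scatter. The steps that link compound 4 to compound 2 and compound 3 cannot be read, even though allyloxy and isopropylsulfanyl have the same count of heavy atoms, because those two compounds carry only limits: the limit of > 20000 nM in this assay, at which 2 of the 4 values shown sit.

As far as these compounds go, how the sulfur-linked compounds truly compare with the allyloxy and isobutylamino compounds remains open, as no number stands for either of the latter two. The compounds shown also do not tell whether a longer chain on the sulfur, such as hexyl, or a chain ending in a carboxylic acid would stay within the scatter of compound 1 and compound 4.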